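This account rests on a few compounds, and the source may have more. Where it says the series, first, only, none or still open, it means among the compounds named here.

In a functional assay on HeLa cells (Homo sapiens) for antiproliferative activity, read by MTT assay, with a stated time of 3 days (a higher number here means a weaker inhibitor, a lower number a stronger inhibitor), compound 1 `O=C1c2ccccc2C(=O)N1C/C=C\Cn1cc(C#Cc2ccc(Br)cc2)c(=O)[nH]c1=O` gives 87000 nM, a weak result. Compound 2 `CCCCCCCCC#Cc1cn(C/C=C/CN2C(=O)c3ccccc3C2=O)c(=O)[nH]c1=O` reads > 100000 nM, which is a limit of the assay and not a number.

Compound 3 `O=C1c2ccccc2C(=O)N1C/C=C/Cn1cc(C#CCCc2ccccc2)c(=O)[nH]c1=O` keeps the shared core and alters the chain on the triple bond of compound 2: phenyl in place of hexyl on a saturated chain carbon, two bonds along the chain from a triple-bonded carbon. Put simply, this is phenyl in place of hexyl on a saturated chain carbon, two bonds along the chain from a triple-bonded carbon, so dec-1-yn-1-yl becomes 4-phenylbut-1-yn-1-yl.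

Among the compounds with values here, no measured pair shows what this swap does. The closest guide is compound 1, which also carries an aromatic ring on the triple bond, though it differs in other ways too, and it gives 87000 nM. That single value suggests only a small move toward a stronger inhibitor, and the result may well stay at the limit. The expected change in this assay is an estimated at least 1.3-fold lower number from compound 2 to compound 3 (0.12 log units; that floor lies within the scatter). The estimated value for compound 3 is 75000 nM, with an expected range of 30000 nM to 150000 nM.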

Compound 3, half-maximal inhibitory concentration: 29000 nM
Beside the measured number, compound 3's estimate is 2.6-fold (0.41 log units) above it; the measured number lies below the stated range.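

In this assay, within the data shown here, phenyl in place of hexyl on a saturated chain carbon, two bonds along the chain from a triple-bonded carbon, gives an at least 3.4-fold lower number from compound 2 to compound 3 (0.53 log units; beyond the scatter), the first change that can be read from a pair differing in one place. The step is reported only as a minimum because compound 2 stands at a limit of the assay rather than at a number: the limit of > 100000 nM in this assay, at which 1 of the 3 values shown sits. Since phenyl and hexyl hold the same count of heavy atoms, all of them carbon, that count cannot separate them, and the step shows that the identity of the group at this place on the chain can change the result beyond the usual scatter, though compound 3 still needs a high concentration to act.

This is a single pair, so it cannot say whether the ring itself or its aromatic character accounts for the step, which a cyclohexyl group at the same place could begin to address. Also open, from the compounds shown here alone, is how the result would respond to an amine or a carboxylic acid on the phenyl ring, or to a longer chain leading to that ring.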